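A few compounds are considered here, and "the series" means these few. Any claim that something is new, unique, unknown or untested is made for them only; others in the source may bear on it.

Of the compounds shown here, three have been measured in a functional assay on OVCAR-3 cells (Homo sapiens) for cytotoxicity, read by sulforhodamine B assay, with a stated time of 48 h, tested at 1 uM; a lower number here means a stronger effect, a higher number a weaker effect of the compound at the concentration tested. Compound 1 `COc1cc(-c2cc(/C=C/C(=O)c3ccc(N)cc3)[nH]n2)cc(OC)c1OC` gives 79% in this assay. Compound 2 `COc1ccc(-c2cc(/C=C/C(=O)c3ccc(N)cc3)[nH]n2)cc1OC` differs from compound 1 in one place, (hydrogen in place of methoxy on an aromatic carbon), and in this assay compound 2 gives 92%. That single change made a step of a number 13 percentage points higher from compound 1 to compound 2 (beyond the scatter), so taking away the methoxy group left a somewhat weaker effect at the concentration tested. Compound 3 `COc1cc(C(=O)/C=C/c2cc(-c3cc(OC)c(OC)c(OC)c3)n[nH]2)cc(OC)c1OC` is built on a different core; in this assay compound 3 gives 97%, a figure within the scatter of the number for compound 2 and beyond the scatter of the number for compound 1. The difference between the core of compound 3 and the core of compound 1 is not broken down here.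

Compound 4 `COc1ccc(-c2cc(/C=C/C(=O)c3cc(OC)c(OC)c(OC)c3)[nH]n2)cc1OC` has not yet been measured. Going by the values given here, it differs from compound 3 by hydrogen in place of methoxy on an aromatic carbon, which is the same change as the one from compound 1 to compound 2, with the same surroundings at the place of change in both cases. Because the earlier change made a step of a number 13 percentage points higher from compound 1 to compound 2 (beyond the scatter) and because compound 3 already gives 97%, leaving little room for a weaker reading, only a small further step is expected, a number 3 percentage points higher from compound 3 to compound 4 (within the scatter). Compound 4 is therefore expected to give 100% in this assay, with a likely range from 90% to 108%.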

Compound 4, a percentage reported as activity, at one concentration (the size of the read-out at that concentration, not a potency): 84%
Estimate against measurement, compound 4: 16 percentage points above; measured number below the stated range.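

Taking the methoxy group away from the ring of compound 3 gave a number 13 percentage points lower from compound 3 to compound 4 (beyond the scatter) in this assay, so on this core the change left a somewhat stronger effect at the concentration tested, whereas on the core of compound 1 it left a somewhat weaker one. Set side by side, the two results show that the effect of this change does not carry over from one core to the other in this series, even though the surroundings at the place of change are the same: the same change on two cores in this assay, a number 13 percentage points higher (beyond the scatter) from compound 1 to compound 2 and a number 13 percentage points lower (beyond the scatter) from compound 3 to compound 4, 26 percentage points apart, beyond the scatter of two such steps This rests on only two pairs of compounds read at a single concentration, so it shows neither why the direction reverses nor how much of the change in potency, if any, lies behind these readings.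

The compounds shown leave open which part of the two cores decides the direction of the step, and whether a third core would follow either one. They also leave open how a hydroxy group, a chlorine atom or an ethoxy group at this same place would read on each core.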